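Bromine on the pyrazole: a small change to compound 3

The source may hold more compounds than are shown below. What is called first, only, known or untested is meant among the compounds shown, and "the series" means these compounds.

Measured compounds:
- compound 1 `CCN(C)C(=O)C1CCN(c2cncnc2-c2ccccc2)CC1`: 14 nM
- compound 2 `CN(C)C(=O)C1CCN(c2cncnc2-c2ccc(F)cc2)CC1`: 7.3 nM
- compound 3 `CN(C)C(=O)C1CCN(c2cnccc2-n2cccn2)CC1`: 48 nM

In an assay on HEK293F cells for inhibition of cholesterol 24-hydroxylase (Homo sapiens), read by trypan blue exclusion, with stated times of 15 min and 5 h (on this read-out higher numbers stand for weaker inhibition and lower numbers for stronger inhibition), compound 3 gives the highest number of the three, so it is the weakest inhibitor shown; compound 1 sits nearest to it and compound 2 furthest away, both gaps beyond the scatter.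

Compound 4 `CN(C)C(=O)C1CCN(c2cnccc2-n2cc(Br)cn2)CC1` differs from compound 3 in one place: bromo in place of hydrogen on an aromatic carbon. Going by the values given here, no measured pair shows this same change, so nothing here tells its direction. From compound 3 to compound 4 a modest gain in potency is expected, as a 1.9-fold lower number from compound 3 to compound 4 (0.28 log units; within the scatter), yet a step within the scatter would not surprise. Compound 4 is therefore estimated at 25 nM, with a range from 8 nM to 80 nM.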

Compound 4, half-maximal inhibitory concentration: 9.5 nM
Beside the measured number, compound 4's estimate is 2.6-fold (0.42 log units) above it; low and high end bracket the measured number.
By their numbers in this assay, from the lowest: compounds 2, 4 and 1 (each within the scatter of the next); then compound 3.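

This position tolerates more than a hydrogen: in this assay, the change from 1H-pyrazol-1-yl to 4-bromo-1H-pyrazol-1-yl gives a 5.1-fold lower number from compound 3 to compound 4 (0.70 log units; beyond the scatter). It is the only single-place step shown, and it ties stronger inhibition to one added bromine atom on this aromatic carbon. Nothing measured here accounts for the change.

From the compounds shown here alone, whether bromine itself matters remains open, since chloro, methyl or nitrile on the same carbon would show if other groups do as well. Going by these compounds, the same change on the other cores also remains untested here.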